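This account rests on a few compounds, and the source may have more. Where it says the series, first, only, none or still open, it means among the compounds named here.

Of the compounds shown here, three built on one shared core have been measured in a functional assay on MCF7 cells (Homo sapiens) for antiproliferative activity, read by MTT assay, with a stated time of 48 h; a higher number here means a weaker inhibitor, a lower number a stronger inhibitor. Compound 1 `Clc1ccc(C2=NN(c3nc(-c4ccc(Br)cc4)cs3)C(c3ccc4c(c3)OCCO4)C2)cc1` gives 2230 nM, compound 2 `COc1ccc(-c2csc(N3N=C(c4ccc(Br)cc4)CC3c3ccc4c(c3)OCCO4)n2)cc1` gives 870 nM, and compound 3 `COc1ccc(-c2csc(N3N=C(c4ccc(Cl)cc4)CC3c3ccc4c(c3)OCCO4)n2)cc1` gives 3030 nM. Compound 2 stands lowest of the three, and the step from compound 2 to compound 3 is a 3.5-fold higher number from compound 2 to compound 3 (0.54 log units; beyond the scatter). Compound 3 and compound 1 differ by a single change, (bromo in place of methoxy on an aromatic carbon), and that step is a 1.4-fold lower number from compound 3 to compound 1 (0.13 log units; within the scatter), so it did not move the number in a way that can be told from repeat scatter.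

Compound 4 `Brc1ccc(C2=NN(c3nc(-c4ccc(Br)cc4)cs3)C(c3ccc4c(c3)OCCO4)C2)cc1` has not yet been measured in this assay. Within the data shown here, it differs from compound 2 by bromo in place of methoxy on an aromatic carbon, which is the same change as the one from compound 3 to compound 1, made at the same place. The cores of the two pairs differ by bromo in place of chloro on an aromatic carbon.

Because the earlier step of a 1.4-fold lower number from compound 3 to compound 1 (0.13 log units; within the scatter) stayed within the scatter, compound 4 is expected to sit close to its parent, and the expected step is a 1.3-fold lower number from compound 2 to compound 4 (0.13 log units; within the scatter). For compound 4 the estimate in this assay is 650 nM, expected to fall between 300 nM and 1500 nM.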

Compound 4, half-maximal inhibitory concentration: 320 nM
Compound 4: the middle estimate sits 2.0-fold (0.31 log units) above what was measured; the measured number falls inside the stated range.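

Changing 4-methoxyphenyl to 4-bromophenyl gives a 2.7-fold lower number from compound 2 to compound 4 (0.43 log units; beyond the scatter) in this assay, and this step can be set beside the same change on the core that carries chloro: the same change on two cores in this assay, a 1.4-fold lower number (0.13 log units; within the scatter) from compound 3 to compound 1 and a 2.7-fold lower number (0.43 log units; beyond the scatter) from compound 2 to compound 4, 2.0-fold (0.30 log units) apart, within the scatter of two such steps. Exchanging chloro for bromo on the other aromatic ring gives a 7.0-fold lower number from compound 1 to compound 4 (0.84 log units; beyond the scatter), and that exchange also carries over between two cores: the same change on two cores in this assay, a 3.5-fold higher number (0.54 log units; beyond the scatter) from compound 2 to compound 3 and a 7.0-fold higher number (0.84 log units; beyond the scatter) from compound 4 to compound 1, 2.0-fold (0.30 log units) apart, within the scatter of two such steps. These four compounds therefore give no sign that either change behaves differently on the two cores, but this rests on a single pair of steps for each change, and it does not show that the agreement would hold on any further core or explain how either change acts.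

The compounds shown carry only methoxy, bromo and chloro at these two places, so it remains open how an amine, a carboxylic acid or a longer chain would behave there. Whether the two changes would still add up in the same way with such groups is also unknown.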